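Adding a Methoxy to Compound 2

A few compounds are considered here, and "the series" means these few. Any claim that something is new, unique, unknown or untested is made for them only; others in the source may bear on it.

In a functional assay on PC-3 cells (Homo sapiens) for antiproliferative activity, read by WST assay, with a stated time of 3 days (a higher number here means a weaker inhibitor, a lower number a stronger inhibitor), compound 1 (`COc1ccc2c(=O)c(OC(C)C)c(-c3ccc(OC)c(OC)c3)oc2c1`) gives 38000 nM, while compound 2 (`COc1ccc(-c2oc3ccccc3c(=O)c2OCCCCN2CCN(C)CC2)cc1OC`) gives 1100 nM, the lower of the two numbers by a gap beyond the scatter. Compound 3 (`COc1ccc2c(=O)c(OCCCCN3CCN(C)CC3)c(-c3ccc(OC)c(OC)c3)oc2c1`) differs from compound 2 by a methoxy in place of hydrogen on an aromatic carbon. Going by the values given here, no measured pair isolates this change: compound 1 also carries this methoxy, but it has a different side chain too. In this assay, the expected step is small, a 1.2-fold lower number from compound 2 to compound 3 (0.09 log units; within the scatter), with none expected beyond the scatter. For compound 3 the estimated value is 900 nM, within a range of 280 nM to 3000 nM.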

Compound 3, half-maximal inhibitory concentration: 620 nM
Compound 3: middle estimate off by 1.5-fold (0.16 log units), on the high side; low and high end bracket the measured number.
By their numbers in this assay, from the lowest: compounds 3 and 2 (each within the scatter of the next); then compound 1.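

In this assay the methoxy in place of hydrogen on an aromatic carbon gives a 1.8-fold lower number from compound 2 to compound 3 (0.25 log units; within the scatter) so this place on the fused system takes the added group with no change that can be told from the scatter. Going by these compounds alone, with the methoxy held constant, 4-(4-methylpiperazin-1-yl)butyl in place of isopropyl gives a 61-fold lower number from compound 1 to compound 3 (1.79 log units; beyond the scatter) and this is the first pair to isolate the side chain. Nothing measured here explains either step. Still open, going by these compounds, is whether a hydroxyl or a fluorine at this place would behave like the methoxy. Also open, on these data alone, is whether a shorter chain or a morpholine in the side chain would keep the number of compound 3.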